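The compounds below may be only part of what the source reports. "The series", "measured", "known", "first", "only" and "open" are said of these compounds alone.

Measured so far in an in vitro functional assay on 1321-N1 cells for agonist activity at Free fatty acid receptor 1 (Homo sapiens), read by fluorescence, spectrophotometry and calcium flux; a lower number here means that less compound is needed, a higher number that more compound is needed for the effect:

Compound 1 `O=C(O)CCc1ccc(C#Cc2ccnc(Cl)c2)cc1`: 295 nM
Compound 2 `O=C(O)CCc1ccc(C#Cc2ccnc(Cl)n2)cc1`: 9120 nM
Compound 3 `COc1cc(C#Cc2ccc(CCC(=O)O)cc2)ccn1`: 525 nM

Compound 1 and compound 2 share the acid-bearing arm and the alkyne link but carry different cores; the difference between the two cores is not broken down here. Compound 2 gives the highest number of the three, beyond the scatter against both compound 1 and compound 3, so the core of compound 2 is the weaker of the two in this assay.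

From compound 1 to compound 3 the change is methoxy in place of chloro on an aromatic carbon. The step is a 1.8-fold higher number from compound 1 to compound 3 (0.25 log units; within the scatter), so the exchange on the core of compound 1 is close to neutral.

Compound 4 `COc1nccc(C#Cc2ccc(CCC(=O)O)cc2)n1` applies the same kind of change to the core of compound 2: methoxy in place of chloro on an aromatic carbon. The surroundings are not identical: on compound 1 the change sits on a six-membered aromatic ring with 1 nitrogen, next to the ring nitrogen, whereas on compound 2 it sits on a six-membered aromatic ring with 2 nitrogen, between two ring nitrogen atoms; in both cases it is meta to a large group.

With one precedent only, the expectation is a step of similar size. The step from compound 2 to compound 4 is expected to be a 1.5-fold higher number from compound 2 to compound 4 (0.19 log units; within the scatter). Compound 4 is expected to give 14000 nM, within 5000 nM to 40000 nM, because the same kind of change gave a 1.8-fold higher number from compound 1 to compound 3 (0.25 log units; within the scatter).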

Compound 4, half-maximal effective concentration: 9550 nM
For compound 4 the middle estimate is 1.5-fold (0.17 log units) above the measured one; the range from low to high includes it.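

In this assay, methoxy in place of chloro on an aromatic carbon between two ring nitrogen atoms gives a 1.0-fold higher number from compound 2 to compound 4 (0.02 log units; within the scatter), so the exchange is close to neutral on this core as well. The two steps cannot be told apart, and on these two cores the exchange carries over as a change with no readable effect: the same change on two cores in this assay, a 1.8-fold higher number (0.25 log units; within the scatter) from compound 1 to compound 3 and a 1.0-fold higher number (0.02 log units; within the scatter) from compound 2 to compound 4, 1.7-fold (0.23 log units) apart, within the scatter of two such steps. This rests on two cores only and says nothing about any other core or any other group at this place; nor does the exchange close the distance between the two cores, with compound 3 at 525 nM and compound 4 at 9550 nM.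

The compounds shown leave open whether the same neutral result holds on these cores for an amine, a methyl group or a longer alkoxy chain such as ethoxy in place of chloro. They also leave open how far the series tolerates change elsewhere, for example an amide in place of the carboxylic acid or a longer chain between the carboxylic acid and the benzene ring.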